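The compounds below may be only part of what the source reports. "The series", "measured", "known", "first", "only" and "open" are said of these compounds alone.

Measured so far in a functional assay on B16-F10 cells (Mus musculus) for inhibition, read by MTT assay, with a stated time of 72 h; on this read-out higher numbers stand for weaker inhibition and lower numbers for stronger inhibition:
- Compound 1 `CC1(C)CC(NC(=S)Nc2ccc(C#N)cc2)c2cc(Cl)ccc2O1`: 7000 nM
- Compound 2 `CC1(C)CC(NC(=S)Nc2ccc([N+](=O)[O-])cc2)c2cc(Cl)ccc2O1`: 3000 nM

Of these two numbers, compound 1 holds the higher, 7000 nM, which makes it the weaker inhibitor of the pair. The next analogue, compound 3 `CC1(C)CC(NC(=S)Nc2cccc(C#N)c2)c2cc(Cl)ccc2O1`, carries the same atoms joined differently, with 3-cyanophenyl in place of 4-cyanophenyl on an amide-type nitrogen.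

For the measured compounds named here, only one measured step bears on this change, and only loosely, since it replaces the group rather than moving it. Going by the values given here, no measured pair shows a nitrile moved around the ring. That step is a 2.3-fold lower number from compound 1 to compound 2 (0.37 log units; beyond the scatter), and its modest size gives no support for expecting a large change in this assay. It also does not show which way a move of the nitrile would go, so only a small shift is expected, placed tentatively toward a lower number. The expected step is a 1.4-fold lower number from compound 1 to compound 3 (0.15 log units; within the scatter), which would not lie beyond the scatter. For compound 3 the estimated value is 5000 nM, with an expected range from 2000 nM to 12000 nM.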

Compound 3, half-maximal inhibitory concentration: 6000 nM
Estimate against measurement, compound 3: 1.2-fold (0.08 log units) below, and the stated range covers the measured number.
By their numbers in this assay, from the lowest: compounds 2, 3 and 1 (each within the scatter of the next, the first and the last beyond it).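

In this assay, 3-cyanophenyl in place of 4-cyanophenyl on the amide-type nitrogen gives a 1.2-fold lower number from compound 1 to compound 3 (0.07 log units; within the scatter), so the two placements of the nitrile cannot be told apart on this read-out. For the compounds shown here, this pair is the first to test a change of place for the group rather than a change of the group itself, and its step lies within the scatter, whereas nitro in place of cyano gives a 2.3-fold lower number from compound 1 to compound 2 (0.37 log units; beyond the scatter), which lies beyond it. Among the compounds shown, then, only the change of group moves the number beyond the scatter, although that step is modest and rests on a single pair, and nothing available explains why the change of place leaves the two numbers within the scatter of each other.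

The compounds shown leave open whether a nitro group would also stay within the scatter if placed as the nitrile is in 3-cyanophenyl. They also leave open what an amine or a carboxylic acid on this aromatic ring would do to the number, and whether a carbonyl could stand in place of the thiocarbonyl.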